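From 4-Fluorophenyl to 2,6-Difluorophenyl: An Expected Limit

The compounds below may be only part of what the source reports. "The series", "measured", "known", "first", "only" and "open" are said of these compounds alone.

Compound 1, `N#CC1=C(N)Oc2c(c3nc4ccccc4nc3c3ccccc23)C12C(=O)N(Cc1cnnn1-c1cccc(Cl)c1)c1ccccc12`, in an ADME assay on HUVEC cells (Homo sapiens) for antiproliferative activity, read by MTT assay, with a stated time of 48 h (on this read-out higher numbers stand for weaker inhibition and lower numbers for stronger inhibition), gives > 50000 nM, which is a limit of the assay and not a number.
Compound 2, `Cc1ccc(-n2nncc2CN2C(=O)C3(C(C#N)=C(N)Oc4c3c3nc5ccccc5nc3c3ccccc43)c3ccccc32)cc1C`, in this assay gives > 50000 nM, again a limit.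
Compound 3, `N#CC1=C(N)Oc2c(N)cc3nc4ccccc4nc3c2C12C(=O)N(Cc1cnnn1-c1ccc(F)cc1)c1ccccc12`, in this assay gives > 50000 nM, also a limit.

Going by the values given here, the one step between measured compounds that differ in a single place, a step that the two limits leave unreadable from compound 1 to compound 2, is unreadable because both ends sit at the limit. Compound 3 therefore stands exactly where every other value in this set stands, at the limit of > 50000 nM in this assay, at which 3 of the 3 values shown sit.

Compound 4, `N#CC1=C(N)Oc2c(N)cc3nc4ccccc4nc3c2C12C(=O)N(Cc1cnnn1-c1c(F)cccc1F)c1ccccc12`, differs from compound 3 by 2,6-difluorophenyl in place of 4-fluorophenyl on an aromatic nitrogen. Among the compounds with values here, the only measured step at this aromatic nitrogen gives no readable size, so no change beyond the scatter can be inferred. Because all three compounds sit at the limit of > 50000 nM in this assay, at which 3 of the 3 values shown sit, compound 4 is expected to remain there as well, and the step of a number no higher from compound 3 to compound 4 (the limit leaves the size open) is expected to show no change beyond the scatter. For compound 4 in this assay an estimate of 50000 nM is expected, within a range from 20000 nM to 100000 nM, most likely reported again only as a limit.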

Compound 4, half-maximal inhibitory concentration: > 50000 nM
Compound 4: only a limit was reported; the forecaster's own chance of this, stated with the estimate: 85%; the middle value sits exactly at the limit.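

In this assay the step from compound 3 to compound 4 cannot be read, since both compounds give only a limit and not a number: (the limit of > 50000 nM in this assay, at which 4 of the 4 values shown sit). The compounds shown leave open whether any group on this aromatic nitrogen, or any change to the shared core, would give a measurable value.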